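Branching the Side Chain: From Methyl to Isopropyl

This account rests on a few compounds, and the source may have more. Where it says the series, first, only, none or still open, it means among the compounds named here.

All four compounds share one core and differ only in the ester-bearing side chain. Compound 2 `COC(=O)[C@@H](C)NC(=O)Cn1cc(C2=C(c3c[nH]c4ccccc34)C(=O)N(C)C2=O)c2ccccc21` gives 30500 nM in a functional assay on A549 cells (Homo sapiens) for cytotoxicity, read by MTT assay, with a stated time of 24 h (on this read-out lower numbers stand for stronger inhibition and higher numbers for weaker inhibition), the lowest of the two numbers measured, with compound 3 `COC(=O)CCNC(=O)Cn1cc(C2=C(c3c[nH]c4ccccc34)C(=O)N(C)C2=O)c2ccccc21` close by at 37600 nM. Compound 1 `CC[C@H](C)[C@@H](NC(=O)Cn1cc(C2=C(c3c[nH]c4ccccc34)C(=O)N(C)C2=O)c2ccccc21)C(=O)OC` reaches only a limit, > 100000 nM, in this assay. Compound 4 `COC(=O)[C@H](NC(=O)Cn1cc(C2=C(c3c[nH]c4ccccc34)C(=O)N(C)C2=O)c2ccccc21)C(C)C` carries the change (isopropyl in place of methyl on a saturated chain carbon bound to an amide-type nitrogen and a carbonyl carbon). The measured steps point one way: an at least 3.2-fold lower number from compound 1 to compound 2 (0.51 log units; beyond the scatter) and an at least 2.6-fold lower number from compound 1 to compound 3 (0.42 log units; beyond the scatter), while a 1.2-fold higher number from compound 2 to compound 3 (0.09 log units; within the scatter). Because an at least 3.2-fold lower number from compound 1 to compound 2 (0.51 log units; beyond the scatter) was seen when sec-butyl was cut down to methyl, and compound 4 moves back toward a branched chain, a weaker result than compound 2 is expected, possibly again a limit like (the limit of > 100000 nM in this assay, at which 1 of the 3 values shown sits). Compound 4 is therefore estimated at 65000 nM, ranging from 30000 nM to 150000 nM, an expected 2.1-fold higher number from compound 2 to compound 4 (0.33 log units; beyond the scatter).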

Compound 4, half-maximal inhibitory concentration: 30600 nM
Compound 4: the middle estimate sits 2.1-fold (0.33 log units) above what was measured; the measured number falls inside the stated range.
By their numbers in this assay, from the lowest: compounds 2, 4 and 3 (each within the scatter of the next). At a limit, above all of these: compound 1.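

Isopropyl in place of methyl on this saturated chain carbon leaves no readable change, with a 1.0-fold higher number from compound 2 to compound 4 (0.00 log units; within the scatter), and the 2-(methoxycarbonyl)ethyl chain also sits within the scatter, with a 1.2-fold lower number from compound 3 to compound 4 (0.09 log units; within the scatter). Branching on this carbon is therefore tolerated up to isopropyl, whereas hydrogen in place of methyl, three bonds along the chain, gives an at least 3.2-fold lower number from compound 1 to compound 4 (0.51 log units; beyond the scatter), so that one further methyl separates these two compounds. The value of compound 1 is a limit: the limit of > 100000 nM in this assay, at which 1 of the 4 values shown sits.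

On these data alone, what a carboxylic acid in place of the methyl ester, or a benzyl group on this chain carbon, would give remains open.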